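Chloro in place of phenyl on the shared core

This account rests on a few compounds, and the source may have more. Where it says the series, first, only, none or still open, it means among the compounds named here.

Compound 1 `c1ccc(Sc2c(-c3ccccc3)nc3ccc(-c4ccccc4)cn23)cc1` was tested in a functional assay on U-87MG ATCC cells for inhibition, with U-87 MG (Homo sapiens) as the target, read by MTT assay, with a stated time of 48 h (on this read-out lower numbers stand for stronger inhibition and higher numbers for weaker inhibition), and returned only a limit, > 100000 nM, so its standing is given by the limit of > 100000 nM in this assay, at which 1 of the 2 values shown sits, rather than by a number. Compound 2 `CSc1ccc(-c2nc3ccccn3c2Sc2ccccc2)cc1` gives 26900 nM in this assay. Compound 3 `Clc1ccc2nc(-c3ccccc3)c(Sc3ccccc3)n2c1` differs from compound 1 by chloro in place of phenyl on an aromatic carbon. Going by the values given here, no measured step between such a pair exists here, so the size of an at least 2.0-fold lower number from compound 1 to compound 3 (0.30 log units; that floor lies within the scatter) is an expectation only, toward stronger inhibition but possibly within the scatter. Compound 3 is estimated at 50000 nM, between 15000 nM and 150000 nM.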

Compound 3, half-maximal inhibitory concentration: > 100000 nM
Compound 3 ended at the assay's limit; the forecaster's own chance of this, stated with the estimate: 45%; middle value at least 2.0-fold (0.30 log units) from the limit.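

Compound 3 returned only a limit, > 100000 nM. Going by these compounds alone, compound 1 likewise returned only a limit, > 100000 nM, so no step between the two can be read. As far as these compounds go, whether chloro or phenyl on that aromatic carbon gives stronger inhibition stays open.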